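The source may report more compounds than this note shows. Statements on the series, on what has been measured and on what is new or still open speak of the compounds shown alone.

Measured compounds and values:
- Compound 1 `O=C1Nc2ccc(S(=O)(=O)N3CCOCC3)cc2/C1=N/c1ccc(Br)cc1` gives 11900 nM in a functional assay on HepG2 cells (Homo sapiens) for cytotoxicity, read by sulforhodamine B assay, with a stated time of 24 h; on this read-out higher numbers stand for weaker inhibition and lower numbers for stronger inhibition.
- Compound 2 `O=C1Nc2ccc(S(=O)(=O)N3CCOCC3)cc2/C1=N/c1cccc(C(F)(F)F)c1` gives 14300 nM in this assay.

Compound 2 stands at the top of these two numbers, but only by a step that falls within the scatter: a 1.2-fold higher number from compound 1 to compound 2 (0.08 log units; within the scatter). The two values therefore show no real separation between the 4-bromophenyl and the 3-(trifluoromethyl)phenyl on the double-bonded nitrogen.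

Compound 3 `O=C1Nc2ccc(S(=O)(=O)N3CCOCC3)cc2/C1=N/NS(=O)(=O)c1ccccc1` has not yet been measured in this assay. It differs from compound 2 as follows: (phenylsulfonyl)amino in place of 3-(trifluoromethyl)phenyl on a double-bonded nitrogen. Going by the values given here, the only measured step swaps one six-membered aromatic ring of carbon only for another on the same nitrogen, and it was within the scatter. No measured step introduces a hydrogen-bond donor or a sulfur at this place, so nothing shown here points in either direction for compound 3; the step of a 1.2-fold higher number from compound 1 to compound 2 (0.08 log units; within the scatter) merely suggests that variation at this nitrogen need not move the number much.

Compound 3 is therefore expected to give 15000 nM in this assay, with a range of 5000 nM to 45000 nM, which is expected to mean a 1.0-fold higher number from compound 2 to compound 3 (0.02 log units; within the scatter).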

Compound 3, half-maximal inhibitory concentration: 23900 nM
Beside the measured number, compound 3's estimate is 1.6-fold (0.20 log units) below it; measured number inside the range.
By their numbers in this assay, from the lowest: compounds 1, 2 and 3 (each within the scatter of the next).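

In this assay, the double-bonded nitrogen of the shared core now carries a group of a different kind, yet the number stays within the scatter of both earlier compounds (a 1.7-fold higher number from compound 2 to compound 3 (0.22 log units; within the scatter); a 2.0-fold higher number from compound 1 to compound 3 (0.30 log units; within the scatter)). Going by these compounds alone, until now, only one six-membered aromatic ring of carbon had been exchanged for another directly on this nitrogen, whereas the (phenylsulfonyl)amino group brings a sulfur, a hydrogen-bond donor and hydrogen-bond acceptors that the 3-(trifluoromethyl)phenyl does not carry, and this exchange still produces no separation beyond the scatter. Nothing measured here accounts for the size of these steps.

The compounds shown leave open whether a group with no aromatic ring at this place, such as a simple amine or a carboxylic acid on a longer chain, would move the number beyond the scatter. Every change shown also sits on this one nitrogen, so what a change elsewhere on the shared core would do remains an open question.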